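Swapping a Urea for a Benzyl Amine on an Acid Core

This account rests on a few compounds, and the source may have more. Where it says the series, first, only, none or still open, it means among the compounds named here.

Measured so far:
compound 1, `CNC(=O)c1cnc(NC(=O)NC2CCCCC2)n2nc(-c3ccco3)nc12`, 18700 nM
compound 2, `O=C(Nc1ncc(C(=O)O)c2nc(-c3ccco3)nn12)NC1CCCCC1`, 59400 nM
compound 3, `CCOC(=O)c1cnc(NCCOC)n2nc(-c3ccco3)nc12`, 105 nM

In an assay on CHO cells for displacement of a labelled ligand from adenosine receptor A3 (Homo sapiens) (a lower number here means a stronger inhibitor, a higher number a weaker inhibitor), compound 2 gives the highest number of the three: compound 1 stands nearest, compound 3 farthest below. The step to compound 4, `O=C(O)c1cnc(NCc2ccc(F)cc2)n2nc(-c3ccco3)nc12`, is 4-fluorobenzyl in place of cyclohexylcarbamoyl on a nitrogen on an aromatic ring. For the measured compounds named here, the only measured step, a 3.2-fold higher number from compound 1 to compound 2 (0.50 log units; beyond the scatter), alters the carbonyl group and not the nitrogen substituent, so it does not directly bear on this change. Compound 3 carries a plain amine substituent on that nitrogen, but with an ester rather than an acid, and its value lies far below that of compound 2; two groups differ there at once. Compound 4 keeps the acid and takes a plain amine substituent, so a move toward compound 3 is expected, with a 30-fold lower number from compound 2 to compound 4 (1.47 log units; beyond the scatter) as the expected step. Compound 4 is estimated at 2000 nM, within 300 nM to 15000 nM.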

Compound 4, inhibition constant: 14000 nM
Compound 4: middle estimate off by 7.0-fold (0.85 log units), on the low side; low and high end bracket the measured number.
By their numbers in this assay, from the lowest: compound 3; then compounds 4 and 1 (each within the scatter of the next); then compound 2.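

With the acid kept, 4-fluorobenzyl in place of cyclohexylcarbamoyl on the nitrogen gives a 4.2-fold lower number from compound 2 to compound 4 (0.63 log units; beyond the scatter) in this assay. This is the only step shown at this position, since the earlier step changed the carbonyl group, so it shows that the substituent on this nitrogen can shift the number on the acid core. Nothing available explains the shift.

The compounds shown leave open whether the shift follows from losing the urea or from gaining the aromatic ring. Plain benzyl or cyclohexylmethyl on that nitrogen would help separate the two, and the fluorine's part also remains open.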